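Swapping an Amide for a Sulfonamide on a Shared Core

The source may report more compounds than this note shows. Statements on the series, on what has been measured and on what is new or still open speak of the compounds shown alone.

Of the compounds shown here, three have been tested in an assay on mitochondria for inhibition of HSP60/HSP10 (Homo sapiens); a higher number here means a weaker inhibitor, a lower number a stronger inhibitor. Compound 1, `O=S(=O)(Nc1ccc(-c2nc3cc(NS(=O)(=O)c4cccc(C(F)(F)F)c4)ccc3o2)cc1)c1cccc(C(F)(F)F)c1`, gives 54000 nM. Compound 2, `COc1ccc(S(=O)(=O)Nc2ccc3oc(-c4ccc(NC(=O)c5cccc(C)c5[N+](=O)[O-])cc4)nc3c2)cc1`, gives 72000 nM, the highest of the three numbers; its gap to compound 1 lies within the usual scatter, so the two cannot be told apart. Compound 3, `O=C(Nc1ccc(Sc2nc3ccccc3s2)c(Cl)c1)c1cccc(Br)c1O`, gives 7700 nM, a number far enough from compound 2 to count as a real difference, with compound 3 the stronger inhibitor of that pair.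

Compound 4, `COc1ccc(S(=O)(=O)Nc2ccc3oc(-c4ccc(NS(=O)(=O)c5cc(Br)ccc5OC)cc4)nc3c2)cc1`, is built on the same core as compound 2. The change is (5-bromo-2-methoxyphenyl)sulfonyl in place of (3-methyl-2-nitrophenyl)carbonyl on a nitrogen on an aromatic ring. Among the compounds with values here, no pair of measured compounds differs in just this way, so there is no measured step to lean on. What can be said is that compound 1, which carries a sulfonamide at the matching place, and compound 2, which carries the amide, sit within the scatter of each other in this assay, which points to no change beyond the scatter from the swap.

Compound 4 is therefore expected to give about 60000 nM in this assay, most likely between 25000 nM and 150000 nM, an expected step of a 1.2-fold lower number from compound 2 to compound 4 (0.08 log units; within the scatter).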

Compound 4, half-maximal inhibitory concentration: 67000 nM
The estimate for compound 4 lay 1.1-fold (0.05 log units) below the measured number, within the range that was stated.
By their numbers in this assay, from the lowest: compound 3; then compounds 1, 4 and 2 (each within the scatter of the next).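

In this assay, the swap at this place can now be read directly as one measured step: (5-bromo-2-methoxyphenyl)sulfonyl in place of (3-methyl-2-nitrophenyl)carbonyl on a nitrogen on an aromatic ring gives a 1.1-fold lower number from compound 2 to compound 4 (0.03 log units; within the scatter) and leaves the two compounds indistinguishable. The earlier link between amide and sulfonamide came from compound 1 and compound 2, which differ in more than one place, whereas compound 2 and compound 4 differ only here. Both groups count 12 heavy atoms and one six-membered aromatic ring of carbon only, and the data give no measurement that explains why the two compounds read alike.

This single step replaces the carbonyl and the groups on the ring together, so it cannot show what each part contributes alone, and a sulfonyl carrying the same 3-methyl-2-nitrophenyl ring would be needed to separate them. It also leaves open whether this place tolerates something much smaller or quite different, such as an acetyl group, a free amine or a carboxylic acid.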